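A few compounds are considered here, and "the series" means these few. Any claim that something is new, unique, unknown or untested is made for them only; others in the source may bear on it.

Measured so far:
- compound 1 `CCCCS(=O)(=O)Oc1ccc(/C=C/C(=O)Nc2ccccc2)cc1OC`: 3320 nM
- compound 2 `COc1cc(/C=C/C(=O)Nc2ccc(I)cc2)ccc1OS(=O)(=O)c1ccc(Cl)cc1`: 39400 nM
- compound 3 `COc1cc(/C=C/C(=O)Nc2cccc(C)c2)ccc1OS(=O)(=O)c1ccc(Cl)cc1`: 73500 nM

In a toxicity assay on L02 cells (Homo sapiens) for cytotoxicity, read by MTT assay, with a stated time of 24 h (a lower number here means that less compound is tolerated, a higher number that more compound is tolerated), compound 1 gives the lowest of the three numbers, and both other compounds lie beyond the scatter from it. Compound 4 `CCCCS(=O)(=O)Oc1ccc(/C=C/C(=O)Nc2ccc(Cl)cc2)cc1OC` departs from compound 1 by a single change: chloro in place of hydrogen on an aromatic carbon. Among the compounds with values here, the only measured step that bears on this also alters the aryl group on the amide nitrogen: a 1.9-fold higher number from compound 2 to compound 3 (0.27 log units; within the scatter). Its two compounds carry a different sulfonyl group from compound 1, so it is only a loose guide. No shift beyond the scatter is therefore expected in this assay. The expected step is a 1.2-fold higher number from compound 1 to compound 4 (0.08 log units; within the scatter). For compound 4 the estimated value is 4000 nM, with an expected range from 1500 nM to 11000 nM.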

Compound 4, half-maximal cytotoxic concentration: 81200 nM
Compound 4: middle estimate off by 20-fold (1.31 log units), on the low side; measured number above the stated range.
By their numbers in this assay, from the lowest: compound 1; then compounds 2, 3 and 4 (each within the scatter of the next, the first and the last beyond it).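

In this assay, the change from phenyl to 4-chlorophenyl gives a 24-fold higher number from compound 1 to compound 4 (1.39 log units; beyond the scatter) and so moves the number well beyond the scatter with the entry of a single chlorine atom. Within the data shown here, the only earlier step on this aryl group stayed within the scatter and came with a different sulfonyl group. The data shown offer no evidence that explains this large step.
From the compounds shown here alone, whether a fluoro, a methoxy or an amine in the same place would move the number as far stays open. So does whether chloro would do the same alongside the sulfonyl group carried by compound 2 and compound 3.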